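Benzofuran for Methoxyphenoxy: Expected Fall in Efficacy

The compounds below may be only part of what the source reports. "The series", "measured", "known", "first", "only" and "open" are said of these compounds alone.

Compound 3 `COc1ccccc1Oc1ccc([C@H]2S[C@@H](C)C(=O)Nc3c2c(C)nn3-c2ccccc2C)cc1` gives the largest response of the three measured compounds in an assay on isolated protein for agonist activity at Bile acid receptor (Homo sapiens), read by AlphaScreen, with a stated time of 30 min (a higher number here means a larger maximal response, a lower number a smaller maximal response), at 240%. Compound 2 `Cc1ccccc1-n1nc(C)c2c1NC(=O)[C@H](C)S[C@@H]2c1ccc(-c2ccsc2)cc1` gives 68% and compound 1 `CCOc1cccc(-c2ccc([C@H]3S[C@@H](C)C(=O)Nc4c3c(C)nn4-c3ccccc3C)cc2)c1` gives 13%, so compound 3 stands well above both. Compound 4 `Cc1ccccc1-n1nc(C)c2c1NC(=O)[C@H](C)S[C@@H]2c1ccc(-c2cc3ccccc3o2)cc1` differs from compound 3 by 1-benzofuran-2-yl in place of 2-methoxyphenoxy on an aromatic carbon. Among the measured compounds shown here, two measured steps bear on this change: a number 172 percentage points higher from compound 2 to compound 3 (beyond the scatter) and a number 227 percentage points higher from compound 1 to compound 3 (beyond the scatter). Both steps swapped a group with one aromatic ring alone for the 2-methoxyphenoxy group and both brought large gains. Compound 4 returns to a group without that 2-methoxyphenoxy, so a large fall is expected: a number 180 percentage points lower from compound 3 to compound 4 (beyond the scatter). Compound 4 is therefore estimated at 60%, within a range from 15% to 150%.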

Compound 4, largest response reached (reported as efficacy), in percent of the reference or control that the assay uses: 17%
The estimate for compound 4 lay 43 percentage points above the measured number; the measured number falls inside the stated range.
By their numbers in this assay, from the lowest: compounds 1 and 4 (each within the scatter of the next); then compound 2; then compound 3.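

In this assay, 1-benzofuran-2-yl holds as many heavy atoms as 2-methoxyphenoxy, yet the swap gives a number 223 percentage points lower from compound 3 to compound 4 (beyond the scatter) at this place, so that count alone does not preserve the large response. The same group also gives a number 51 percentage points lower from compound 2 to compound 4 (beyond the scatter) against thiophen-3-yl, while a number 4 percentage points higher from compound 1 to compound 4 (within the scatter) leaves it level with 3-ethoxyphenyl. No measurement shown explains why 2-methoxyphenoxy stands apart.

Open, from the compounds shown here alone, is whether the linking oxygen or the methoxy group of 2-methoxyphenoxy carries the response, and how an unsubstituted phenoxy or a benzyloxy group would compare here.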